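Working notes: benzylsulfanyl to methylsulfanyl on a shared core

The source may hold more compounds than are shown below. What is called first, only, known or untested is meant among the compounds shown, and "the series" means these compounds.

compound 1, `Cc1nnc(SCc2ccccc2)n1N1C(=O)c2ccccc2C1=O`: > 200000 nM
compound 2, `CCc1nnc(SCc2ccccc2)n1N1C(=O)c2ccccc2C1=O`: > 200000 nM

Both measured values in a functional assay on HepG2 cells (Homo sapiens) for cytotoxicity, read by MTT assay, with a stated time of 48 h (on this read-out higher numbers stand for weaker inhibition and lower numbers for stronger inhibition), are limits of the assay, not numbers. In this assay compound 1 gives > 200000 nM, a limit. Compound 2 gives > 200000 nM, likewise a limit. The step that the two limits leave unreadable from compound 1 to compound 2 is therefore not readable, since both values sit at the limit of > 200000 nM in this assay, at which 2 of the 2 values shown sit. Compound 3, `CCc1nnc(SC)n1N1C(=O)c2ccccc2C1=O`, differs from compound 2 by hydrogen in place of phenyl on a saturated chain carbon bound to a sulfur. Among the measured compounds shown here, no measured step bears on this change, and the values shown give no direction. The expected step is a number no higher from compound 2 to compound 3 (the limit leaves the size open), none beyond the scatter, with compound 3 most likely again reported only as a limit. Compound 3 is estimated at 200000 nM, range 100000 nM to 400000 nM.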

Compound 3, half-maximal inhibitory concentration: > 200000 nM
Compound 3 was reported as a limit; the forecaster's own chance of this, stated with the estimate: 85%; the middle value lies on the limit itself.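

No step can be read from compound 2 to compound 3, since both values in this assay are limits: the limit of > 200000 nM in this assay, at which 3 of the 3 values shown sit.

The compounds shown leave open how benzylsulfanyl and methylsulfanyl compare on the shared core once a numerical value is available.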